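Replacing 2-chloro-4-fluorophenyl with 2-nitrophenyl in compound 1

The source may hold more compounds than are shown below. What is called first, only, known or untested is meant among the compounds shown, and "the series" means these compounds.

Measured so far in a functional assay on PC-3 cells (Homo sapiens) for cytotoxicity, read by MTT assay, with a stated time of 72 h; a lower number here means a stronger inhibitor, a higher number a weaker inhibitor:
Compound 1 `COc1cc2ncnc(Nc3ccc(F)c(Cl)c3)c2cc1NC(=O)/C=C/c1ccc(F)cc1Cl`: 32700 nM
Compound 2 `O=C(/C=C/c1cccc(Cl)c1Cl)Nc1cc2c(Nc3ccc(F)c(Cl)c3)ncnc2cc1O[C@H]1CCOC1`: 27500 nM

Among the compounds with values here, with only two measurements, there is very little to compare. Compound 1 gives 32700 nM and compound 2 gives 27500 nM. These two values lie within the usual scatter of each other, so compound 1 cannot be separated from compound 2 in this assay.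

The next compound to consider is compound 3 `COc1cc2ncnc(Nc3ccc(F)c(Cl)c3)c2cc1NC(=O)/C=C/c1ccccc1[N+](=O)[O-]`. It keeps the core of compound 1 and changes a single group, with 2-nitrophenyl in place of 2-chloro-4-fluorophenyl on a double-bonded chain carbon bound to a double-bonded chain carbon.

Within the data shown here, no measured pair isolates a change of this kind, so the evidence is thin. Compound 1 differs from compound 2 in more than one place, yet compound 2 gives 27500 nM, within the scatter of the other value. On that basis, no change beyond the scatter is expected in this assay. The expected step is a 1.3-fold lower number from compound 1 to compound 3 (0.12 log units; within the scatter). For compound 3, the estimated value is 25000 nM, with an expected range of 9000 nM to 60000 nM.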

Compound 3, half-maximal inhibitory concentration: 14300 nM
Estimate against measurement, compound 3: 1.7-fold (0.24 log units) above; the range from low to high includes it.
By their numbers in this assay, from the lowest: compounds 3, 2 and 1 (each within the scatter of the next, the first and the last beyond it).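

In this assay, within the data shown here, the group on the double-bonded chain carbon turns out to matter: 2-nitrophenyl in place of 2-chloro-4-fluorophenyl gives a 2.3-fold lower number from compound 1 to compound 3 (0.36 log units; beyond the scatter), the first comparison here in which only one part of the molecule differs. The earlier pair, compound 1 and compound 2, differs in more than one place and could not show this, whereas this single swap on the core of compound 1 moves the number beyond the usual scatter, though the step is only modest. No measurement shown here accounts for the step, so it stands as an observation without an explanation.

This swap removes the chlorine and the fluorine and brings in the nitro group in one move, so the step cannot be divided between the departing atoms and the arriving group. On these data alone, how an amine or a carboxylic acid in place of the nitro group on this phenyl ring would read in this assay remains open, as does whether the lower number seen with compound 3 would carry over to other groups at this position.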